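Sulfonyl series notes: from compound 2 toward compound 3

This account rests on a few compounds, and the source may have more. Where it says the series, first, only, none or still open, it means among the compounds named here.

Measured in a functional assay on T47D cells (Homo sapiens) for cytotoxicity, read by sulforhodamine B assay, with a stated time of 48 h; a lower number here means a stronger inhibitor, a higher number a weaker inhibitor: compound 1 `Cc1noc(NS(=O)(=O)c2ccc(N/C=C\C(=O)c3cc4ccccc4oc3=O)cc2)c1C` gives 68400 nM; compound 2 `O=C(/C=C\Nc1ccc(S(=O)(=O)Nc2ccc3cn[nH]c3c2)cc1)c1cc2ccccc2oc1=O` gives 96500 nM.

Compound 2 carries the higher of the two numbers, but the step of a 1.4-fold higher number from compound 1 to compound 2 (0.15 log units; within the scatter) lies within the scatter, so the pair cannot be ranked. Compound 3 `Nc1ccc(S(=O)(=O)c2ccc(N/C=C\C(=O)c3cc4ccccc4oc3=O)cc2)cc1` differs from compound 2 by 4-aminophenyl in place of (1H-indazol-6-yl)amino on a sulfonyl sulfur. For the measured compounds named here, the only measured step, a 1.4-fold higher number from compound 1 to compound 2 (0.15 log units; within the scatter), changed the group on the sulfonamide nitrogen without moving the number beyond the scatter; no measured step alters the sulfonyl sulfur itself. In this assay compound 3 is therefore expected to show a 1.2-fold lower number from compound 2 to compound 3 (0.08 log units; within the scatter), with wide uncertainty. The estimate for compound 3 is 80000 nM, ranging from 25000 nM to 250000 nM.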

Compound 3, half-maximal inhibitory concentration: 91900 nM
Compound 3: middle estimate off by 1.1-fold (0.06 log units), on the low side; the range from low to high includes it.
By their numbers in this assay, from the lowest: compounds 1, 3 and 2 (each within the scatter of the next).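

In this assay, 4-aminophenyl in place of (1H-indazol-6-yl)amino on the sulfonyl sulfur gives no change that can be read (a 1.1-fold lower number from compound 2 to compound 3 (0.02 log units; within the scatter)), and the same holds for its replacement of (3,4-dimethyl-1,2-oxazol-5-yl)amino (a 1.3-fold higher number from compound 1 to compound 3 (0.13 log units; within the scatter)). Earlier, only the group on the sulfonamide nitrogen had varied; here the sulfonamide nitrogen itself is gone, with the number still within the scatter. The data offer no explanation for this.

Going by these compounds, whether any group on the sulfonyl sulfur can move the number beyond the scatter stays open. A carboxylic acid or a morpholine there would test this.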